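The source may report more compounds than this note shows. Statements on the series, on what has been measured and on what is new or still open speak of the compounds shown alone.

Compound 1 `C=CC(C)(C)c1[nH]c2ccc(C[C@@H](O)C(C)(C)Cl)cc2c1/C=C1\NC(=O)[C@H](C)NC1=O` is one of three measured compounds in this set. In a functional assay (a lower number here means a stronger inhibitor, a higher number a weaker inhibitor), compound 1 gives 79000 nM. Compound 3 `C=CC(C)(C)c1[nH]c2ccc(CC=C(C)C)cc2c1/C=C1\NC(=O)C(C)(OC)NC1=O` gives 79000 nM in this assay, level with compound 1 at the digits shown, so that the two together hold the lowest numbers of the three. Compound 2 `C=CC(C)(C)c1[nH]c2c(CC=C(C)C)cccc2c1/C=C1\NC(=O)[C@H](C)NC1=O` gives 86000 nM in this assay, the furthest from compound 1, yet that gap lies within the scatter of repeated measurements, so no order among the three can be read from these numbers. The account now turns to compound 4 `C=CC(C)(C)c1[nH]c2ccc(CC=C(C)C)cc2c1/C=C1\NC(=O)[C@H](C)NC1=O`, which has not yet been measured. Compound 4 differs from compound 1 in one place: 2-methylprop-1-en-1-yl in place of 2-chloro-1-hydroxy-2-methylpropyl on a saturated chain carbon bound to an aromatic carbon. Going by the values given here, no step between measured compounds bears on this change; compound 3 carries the entering group but differs from compound 4 elsewhere as well. Since all three numbers sit together, the step of a 1.0-fold higher number from compound 1 to compound 4 (0.01 log units; within the scatter) is expected to stay within the scatter, with no clear direction. Compound 4 is therefore estimated at 80000 nM, within a range from 35000 nM to 180000 nM.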

Compound 4, half-maximal inhibitory concentration: 98000 nM
For compound 4 the middle estimate is 1.2-fold (0.09 log units) below the measured one; measured number inside the range.
By their numbers in this assay, from the lowest: compounds 1, 3, 2 and 4 (each within the scatter of the next).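

Going by these compounds alone, measured in this assay, the replacement of 2-chloro-1-hydroxy-2-methylpropyl by 2-methylprop-1-en-1-yl gives a 1.2-fold higher number from compound 1 to compound 4 (0.09 log units; within the scatter) and is the first step read at this position, on a saturated chain carbon bound to an aromatic carbon. The change removes the chlorine, the hydrogen-bond donor, the hydrogen-bond acceptor and the defined stereocentre of the leaving group, yet the number stays within the scatter. No measurement here explains this result.

The compounds shown leave open whether any other group at this place, such as an amine, a carboxylic acid or a longer chain, would move the number beyond the scatter. They also leave open whether the opposite stereocentre in the 2-chloro-1-hydroxy-2-methylpropyl group would give a different number.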